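Methoxy position change in a T-type calcium channel series

The source may report more compounds than this note shows. Statements on the series, on what has been measured and on what is new or still open speak of the compounds shown alone.

Measured compounds, all in an assay on HEK293 cells for inhibition of Voltage-dependent T-type calcium channel subunit alpha-1G (Homo sapiens), read by patch clamp, tested at 10 uM; a lower number here means less inhibition, a higher number more inhibition at the concentration tested (going by the name of the read-out):
- compound 1 `O=C(CCCN1CCN(c2ccccc2)CC1)Nc1ccc(Cl)cc1`: 75.1%
- compound 2 `O=C(CCCN1CCN(c2ccccc2Cl)CC1)Nc1ccc(Cl)cc1`: 60.5%
- compound 3 `COc1ccccc1N1CCN(CCCC(=O)Nc2ccc(Cl)cc2)CC1`: 84.3%

Compound 3 holds the highest of the three numbers in this assay, but its nearest neighbour, compound 1, lies within the scatter of it, so compound 3 is not set apart from compound 1; only compound 2 sits clearly lower. The steps from the shared core of compound 1 are a number 14.6 percentage points lower from compound 1 to compound 2 (beyond the scatter) and a number 9.2 percentage points higher from compound 1 to compound 3 (within the scatter); between the two substituted compounds the step is a number 23.8 percentage points higher from compound 2 to compound 3 (beyond the scatter).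

Compound 4 `COc1cccc(N2CCN(CCCC(=O)Nc3ccc(Cl)cc3)CC2)c1` is the next compound. It differs from compound 3 in this way: 3-methoxyphenyl in place of 2-methoxyphenyl on an amine nitrogen in a ring. Among the measured compounds shown here, no measured step moves a group from one ring position to another; the steps that bear on it, from compound 1 to compound 3 and from compound 2 to compound 3, both concern the methoxy group on the same position and were small to modest. The expected step is therefore a number 6.3 percentage points lower from compound 3 to compound 4 (within the scatter), i.e. none beyond the scatter, with a slight lean downward. Compound 4 is estimated at 78%, within 60% to 92%.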

Compound 4, a percentage reported as inhibition, at one concentration (the size of the read-out at that concentration, not a potency): 84.1%
Compound 4: the middle estimate sits 6.1 percentage points below what was measured, and the stated range covers the measured number.
By their numbers in this assay, from the lowest: compound 2; then compounds 1, 4 and 3 (each within the scatter of the next).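

In this assay the methoxy group can sit in either placement without a readable change: 3-methoxyphenyl in place of 2-methoxyphenyl gives only a step within the scatter (a number 0.2 percentage points lower from compound 3 to compound 4 (within the scatter)). The 3-methoxyphenyl group also shows no readable difference from the unsubstituted phenyl (a number 9 percentage points higher from compound 1 to compound 4 (within the scatter)), yet it stands clearly apart from 2-chlorophenyl (a number 23.6 percentage points higher from compound 2 to compound 4 (beyond the scatter)), so the lower number of compound 2 is not shared by either methoxy placement. No measurement at hand accounts for this result.

From the compounds shown here alone, whether an ethoxy group or a carboxylic acid in place of methoxy would keep this level remains open, as does the effect of a longer chain on the ring nitrogen. With a single test concentration, whether compound 1, compound 3 and compound 4 would show a stronger or weaker effect than one another at any other concentration also remains unresolved.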